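Replacing the Acetyl Group with a 4-Methoxybenzyl Arm

The compounds below may be only part of what the source reports. "The series", "measured", "known", "first", "only" and "open" are said of these compounds alone.

Compound 1 `O=C1Nc2ccc([N+](=O)[O-])cc2/C1=C\c1cccc(OCc2cn(Cc3ccccc3)nn2)c1`: in a functional assay on A549 cells (Homo sapiens) for inhibition, read by MTT assay, with a stated time of 48 h (a higher number here means a weaker inhibitor, a lower number a stronger inhibitor), compound 1 gives > 50000 nM, which is a limit of the assay, not a number.
Compound 2 `CC(=O)c1ccc2c(c1)/C(=C\c1cccc(OCc3cn(Cc4ccccc4)nn3)c1)C(=O)N2`: in this assay compound 2 gives > 50000 nM, again a limit of the assay.

Within the data shown here, compound 2 therefore stands only at a limit, and so does the one other compound measured beside it; both sit at the limit of > 50000 nM in this assay, at which 2 of the 2 values shown sit. Among the measured compounds shown here, the single measured step, a step that the two limits leave unreadable from compound 1 to compound 2, cannot be read in size or direction, since both ends are limits. The change now followed is 4-methoxybenzyl in place of acetyl on an aromatic carbon, which produces compound 3 `COc1ccc(Cc2ccc3c(c2)/C(=C\c2cccc(OCc4cn(Cc5ccccc5)nn4)c2)C(=O)N3)cc1`. No readable step bears on this change, so no direction can be drawn from the numbers. Compound 3 is therefore expected to stay near the limit as well, with an estimated value of 60000 nM, ranging from 12000 nM to 300000 nM, meaning an expected step that the limit leaves unreadable from compound 2 to compound 3.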

Compound 3, half-maximal inhibitory concentration: > 50000 nM
Compound 3: no number, only a limit; the forecaster's own chance of this, stated with the estimate: 80%; the middle value is on the limit's open side.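

In this assay compound 3 gives > 50000 nM, which is a limit of the assay, so its steps from compound 1 and compound 2 cannot be read. The compounds shown leave open how strongly each inhibits and whether changing this group on the aromatic carbon alters inhibition at all: the limit of > 50000 nM in this assay, at which 3 of the 3 values shown sit.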